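A few compounds are considered here, and "the series" means these few. Any claim that something is new, unique, unknown or untested is made for them only; others in the source may bear on it.

Measured in a functional assay on SW 1116 cells (Homo sapiens) for antiproliferative activity, read by MTT assay, with a stated time of 48 h; a higher number here means that more compound is needed for the effect, a lower number that less compound is needed:
- compound 1 `O=C(CCc1ccccc1)Nc1nnc(-c2ccc3c(c2)OCCO3)s1` gives 16.2 ug/mL
- compound 2 `Nc1ccc(C(=O)Nc2nnc(-c3ccc4c(c3)OCCO4)s2)cc1` gives 41.2 ug/mL

Of these two, compound 2 carries the higher number, at 41.2 ug/mL. Compound 3 `Cc1ccc(C(=O)Nc2nnc(-c3ccc4c(c3)OCCO4)s2)cn1` differs from it on a carbonyl carbon, with 6-methylpyridin-3-yl in place of 4-aminophenyl on a carbonyl carbon. Within the data shown here, the only measured step at this place is modest: a 2.5-fold higher number from compound 1 to compound 2 (0.41 log units; beyond the scatter). That step involves a different exchange and gives no direction for this one, so no change beyond the scatter is expected. The estimate corresponds to an expected 1.4-fold lower number from compound 2 to compound 3 (0.14 log units; within the scatter). Compound 3 is estimated at 30 ug/mL, with an expected range of 12 ug/mL to 75 ug/mL.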

Compound 3, half-maximal effective concentration: > 100 ug/mL
Compound 3 ended at the assay's limit; the forecaster's own chance of this, stated with the estimate: 10%; middle value at least 3.3-fold (0.52 log units) away from the limit.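

In this assay compound 3 gives > 100 ug/mL as a limit and not a number: the limit of > 100 ug/mL in this assay, at which 1 of the 3 values shown sits.
On the carbonyl carbon, 6-methylpyridin-3-yl in place of 4-aminophenyl gives an at least 2.4-fold higher number from compound 2 to compound 3 (0.38 log units; beyond the scatter) and 6-methylpyridin-3-yl in place of phenethyl gives an at least 6.1-fold higher number from compound 1 to compound 3 (0.79 log units; beyond the scatter) on the same core. On these data alone, this position therefore responds to an exchange between two six-membered aromatic rings, which the earlier step from phenethyl to 4-aminophenyl could not show, and the full size of both new steps remains unknown past the limit. As far as these compounds go, whether the difference follows the amine, the ring nitrogen or the methyl stays open. A plain phenyl or pyridin-3-yl on this carbonyl carbon would help separate them.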